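The source may report more compounds than this note shows. Statements on the series, on what has been measured and on what is new or still open speak of the compounds shown alone.

Compound 1 `Fc1cccc(F)c1Cn1ccc2nc(-c3c(F)cccc3F)nc-2c1` — in an ADME assay on MDBK cells (Bos taurus) for cytotoxicity (on this read-out lower numbers stand for higher toxicity in this test and higher numbers for lower toxicity in this test), compound 1 gives > 100000 nM, which is a limit of the assay rather than a number.
Compound 2 `Fc1cccc(Cn2ccc3nc(-c4ccccc4)nc-3c2)c1` — in this assay compound 2 gives > 100000 nM, again a limit of the assay and not a number.

The two measured compounds share a core and differ in more than one place, so they do not form a single-change pair; all that can be said is that both of their values sit at the same limit. Compound 2 thus stands at the edge of what this assay reports, alongside compound 1, as summed up by the limit of > 100000 nM in this assay, at which 2 of the 2 values shown sit.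

Compound 3 `c1ccc(-c2nc3ccn(Cc4ccncc4)cc-3n2)cc1` has not yet been measured. It differs from compound 2 in one place: pyridin-4-yl in place of 3-fluorophenyl on a saturated chain carbon bound to an aromatic nitrogen. Going by the values given here, no measured pair shows what such a change does here, so the size of the step cannot be read from the data; the only guide is that both measured compounds sit at the limit. The expected step from compound 2 to compound 3 in this assay is a number no higher from compound 2 to compound 3 (the limit leaves the size open), that is, none beyond the scatter. Compound 3 is expected to give 100000 nM, in a range from 40000 nM to 300000 nM, and most likely to be reported again as a limit.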

Compound 3, half-maximal cytotoxic concentration: > 100000 nM
Compound 3 gave a limit, no number; the forecaster's own chance of this, stated with the estimate: 80%; the middle value sits exactly at the limit.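

In this assay compound 3 gives > 100000 nM, which is a limit and not a number. Compound 2 sits at a limit too, so no step can be read between compound 2 and compound 3. The compounds shown leave open what pyridin-4-yl in place of 3-fluorophenyl does to the read-out, since every value stands at one mark: the limit of > 100000 nM in this assay, at which 3 of the 3 values shown sit.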